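This account rests on a few compounds, and the source may have more. Where it says the series, first, only, none or still open, it means among the compounds named here.

Compound 2 `COc1cccc2sc(NC(=O)c3ccc(C#N)cc3)nc12` is the cyano member of this pair. In a functional assay on NUGC-3 cells (Homo sapiens) for antiproliferative activity, read by sulforhodamine B assay (on this read-out higher numbers stand for weaker inhibition of growth and lower numbers for stronger inhibition of growth), compound 2 gives only a limit, > 10 ug/mL. Compound 1 `COc1cccc2sc(NC(=O)c3ccc(C(F)(F)F)cc3)nc12` likewise stops at a limit; in this assay compound 1 gives > 10 ug/mL. The step that the two limits leave unreadable from compound 1 to compound 2 thus has no readable size, and the picture is the limit of > 10 ug/mL in this assay, at which 2 of the 2 values shown sit. Compound 3 `COc1cccc2sc(NC(=O)c3ccc([N+](=O)[O-])cc3)nc12` differs from compound 2 by nitro in place of cyano on an aromatic carbon. No measured step sizes this change, so compound 3 is expected to remain near the same limit, with an estimated step that the limit leaves unreadable from compound 2 to compound 3. For compound 3 the estimate is 20 ug/mL, between 8 ug/mL and 50 ug/mL.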

Compound 3, concentration for 50% growth inhibition: > 10 ug/mL
Compound 3 gave a limit, no number (the forecaster's own chance of this, stated with the estimate: 80%); the middle value is on the limit's open side.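

Compound 3 also stops at a limit, so no step among compound 1, compound 2 and compound 3 can be read in this assay: the limit of > 10 ug/mL in this assay, at which 3 of the 3 values shown sit.

The compounds shown leave open how far trifluoromethyl, cyano and nitro differ in their effect on growth, since none of the three gives a readable number.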